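Swapping an Oxime for a Benzoyl Group in Rat Paw Edema

This account rests on a few compounds, and the source may have more. Where it says the series, first, only, none or still open, it means among the compounds named here.

Of the compounds shown here, two have been tested in a functional assay on the whole organism (strain albino) for inhibition, with Rattus norvegicus as the target, read by paw edema, with a stated time of 1 h, at a dose of 0.28 mmol/kg by the oral route; on this read-out lower numbers stand for less inhibition and higher numbers for more inhibition at the one dose given (going by the name of the read-out). Compound 1 `CCn1c(SCC(=O)c2ccccc2)nnc1-c1ccc(OC)cc1` gives 53%. Compound 2 `C=CCn1c(SC/C(=N/O)c2ccccc2)nnc1-c1ccc(OC)cc1` gives 61%, the higher of the two numbers, but the gap to compound 1 lies within the usual scatter, so the two cannot be told apart on this read-out. Compound 3 `C=CCn1c(SCC(=O)c2ccccc2)nnc1-c1ccc(OC)cc1` has not yet been measured. It differs from compound 2 in one place: a group of 8 heavy atoms (7 carbon, 1 oxygen; one six-membered aromatic ring of carbon only) in place of a group of 9 heavy atoms (7 carbon, 1 nitrogen, 1 oxygen; one six-membered aromatic ring of carbon only), on a saturated chain carbon bound to a sulfur. For the measured compounds named here, compound 1 also carries the benzoyl group, while compound 3 shares all its other parts with compound 2; no pair of measured compounds differs in this group alone, so there is no measured step to lean on. The step of a number 6 percentage points lower from compound 2 to compound 3 (within the scatter) is expected to be small, within the scatter, and in either direction. Compound 3 is expected to give about 55%, likely between 40% and 70%, because compound 1 with the same benzoyl group gives 53%.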

Compound 3, a percentage reported as inhibition, in the whole organism at one dose (the size of the read-out at that dose, not a potency): 49%
Compound 3: the middle estimate sits 6 percentage points above what was measured; low and high end bracket the measured number.
By their numbers in this assay, from the lowest: compounds 3, 1 and 2 (each within the scatter of the next, the first and the last beyond it).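

In this assay, for the compounds shown here, putting benzoyl in place of the group of 9 heavy atoms on a saturated chain carbon bound to a sulfur gives a number 12 percentage points lower from compound 2 to compound 3 (beyond the scatter), the first measured step at this place, and it shows that the number does respond to this change. The other change, vinyl in place of methyl on a saturated chain carbon bound to an aromatic nitrogen, gives a number 4 percentage points lower from compound 1 to compound 3 (within the scatter), so on this read-out it cannot be told from no change. No measurement shown here explains the step at the sulfur-side chain.

From the compounds shown here alone, how an amine or a carboxylic acid in place of benzoyl at that carbon would read stays open. So does whether a longer chain in place of vinyl would shift the number beyond the scatter.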